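The source may hold more compounds than are shown below. What is called first, only, known or untested is meant among the compounds shown, and "the series" means these compounds.

Two compounds of the series carry a measurement in a functional assay on U-937 cells (Homo sapiens) for cytotoxicity, read by WST assay, with a stated time of 72 h; on this read-out lower numbers stand for stronger inhibition and higher numbers for weaker inhibition. Compound 1 `CCN(CC)CCCOc1cc2ncnc(Nc3nc4ccc(C(=O)Nc5c(C)cccc5C)cc4s3)c2cc1OC` gives 23700 nM there, and compound 2 `CCN(CC)CCCOc1cc2ncnc(Nc3nc4ccc(C(=O)Nc5c(C)cccc5Cl)cc4s3)c2cc1OC` gives 7300 nM. Among the compounds with values here, the one measured step between them, a 3.2-fold lower number from compound 1 to compound 2 (0.51 log units; beyond the scatter), concerns the amide side of the shared core. On the numbers shown compound 2 stands lowest of the two, with compound 1 nearest. Compound 3 `COc1cc2c(Nc3nc4ccc(C(=O)Nc5c(C)cccc5Cl)cc4s3)ncnc2cc1OCCCN1CCCCC1` differs from compound 2 elsewhere: piperidin-1-yl in place of diethylamino on a saturated chain carbon, three bonds along the chain from an oxygen on an aromatic ring. Within the data shown here, no measured step in this assay touches this part of the molecule; the only step recorded, chloro in place of methyl on an aromatic carbon, leaves the chain and its amine untouched and so says nothing about the change from diethylamino to piperidin-1-yl. With nothing to lean on, the expectation for compound 3 in this assay is a step within the scatter, no change at the digits printed from compound 2 to compound 3 (within the scatter), and a number close to that of compound 2. Compound 3 is therefore estimated at 7300 nM, with a range of 3000 nM to 18000 nM.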

Compound 3, half-maximal inhibitory concentration: 8600 nM
Compound 3: middle estimate off by 1.2-fold (0.07 log units), on the low side; the measured number falls inside the stated range.
By their numbers in this assay, from the lowest: compounds 2 and 3 (each within the scatter of the next); then compound 1.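

In this assay, within the data shown here, the change at the end of the chain gives a 1.2-fold higher number from compound 2 to compound 3 (0.07 log units; within the scatter) and is the first reading at this part of the molecule. On the scaffold of compound 2, the open diethylamino group and the six-membered non-aromatic ring of piperidin-1-yl therefore cannot be told apart at this position. No measured property bears on this result.

Among these compounds, it remains open whether the same exchange would read alike on the amide carrying two methyl groups found in compound 1, as the exchange is seen only with the chloro-bearing amide. Also open, from the compounds shown here alone, is how this assay would respond to a morpholin-4-yl or 4-methylpiperazin-1-yl group at the chain end, to a primary amine there, or to a chain longer than propyl.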